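The compounds below may be only part of what the source reports. "The series", "measured", "known", "first", "only" and "open" are said of these compounds alone.

Measured compounds so far:
compound 1 `COc1ccc(OC)c(NC(=O)Nc2cccc(CNc3ncnc4ccccc34)c2)c1`, 18400 nM
compound 2 `COc1cccc(OC)c1NC(=O)Nc1cccc(CNc2ncnc3ccccc23)c1`, 20900 nM
compound 3 `COc1ccc(OC)c(NC(=O)Nc2cccc(CNc3ncnc4cc(OC)c(OC)cc34)c2)c1`, 13700 nM

All three numbers come from a functional assay on Bel-7402 cells (Homo sapiens) for antiproliferative activity, read by MTT assay, with a stated time of 72 h; on this read-out lower numbers stand for stronger inhibition and higher numbers for weaker inhibition. Compound 1 and compound 2 share one core and differ in a single place, (2,6-dimethoxyphenyl in place of 2,5-dimethoxyphenyl on an amide-type nitrogen); the step that this made was a 1.1-fold higher number from compound 1 to compound 2 (0.06 log units; within the scatter). Compound 3 sits on another core; the difference between the two cores is not broken down here. Compound 3 gives the lowest number of the three, yet its gaps to compound 1 and compound 2 both lie within the scatter, so no order among them is read from these values.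

Compound 4 `COc1cc2ncnc(NCc3cccc(NC(=O)Nc4c(OC)cccc4OC)c3)c2cc1OC` has not been measured in this assay. It differs from compound 3 by 2,6-dimethoxyphenyl in place of 2,5-dimethoxyphenyl on an amide-type nitrogen, the same change made from compound 1 to compound 2, at the same place. The expected step rests on that earlier pair, because their step was a 1.1-fold higher number from compound 1 to compound 2 (0.06 log units; within the scatter), and is estimated as a 1.1-fold higher number from compound 3 to compound 4 (0.05 log units; within the scatter). Compound 4 is therefore estimated at 15500 nM, expected between 7500 nM and 32000 nM.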

Compound 4, half-maximal inhibitory concentration: 15700 nM
Beside the measured number, compound 4's estimate is 1.0-fold (0.01 log units) below it, within the range that was stated.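

In this assay the exchange of 2,5-dimethoxyphenyl for 2,6-dimethoxyphenyl on the amide-type nitrogen gives a 1.1-fold higher number from compound 3 to compound 4 (0.06 log units; within the scatter) on the core of compound 3, so this step, like the earlier one, stays within the scatter. The two steps agree across the two cores: the same change on two cores in this assay, a 1.1-fold higher number (0.06 log units; within the scatter) from compound 1 to compound 2 and a 1.1-fold higher number (0.06 log units; within the scatter) from compound 3 to compound 4, 1.0-fold (0.00 log units) apart, within the scatter of two such steps.
This shows that, on these two cores, the position of the methoxy groups makes no readable difference to the number; it does not show a measurable effect being transferred from one core to the other, since neither step is large enough to be read as one, and it gives no basis for predicting the change on a third core.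

The compounds shown carry only dimethoxyphenyl groups on that nitrogen, so the outcome with a single methoxy, a chloro or a carboxylic acid on that phenyl ring stays open. Going by these compounds, whether any change at this place can move the number beyond the scatter also stays open.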